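The source may report more compounds than this note shows. Statements on the series, on what has been measured and on what is new or still open speak of the compounds shown alone.

Measured compounds:
- compound 1, `Oc1cccc(-c2cc(-c3cccc(Cl)c3)nc(-c3ccccn3)c2)c1` — in a functional assay on T47D cells (Homo sapiens) for cytotoxicity, read by CCK-8 assay and cell counting, with a stated time of 2 days (a lower number here means a stronger inhibitor, a higher number a weaker inhibitor), compound 1 gives "not determined" (no result reported)
- compound 2, `Oc1cccc(-c2cc(-c3cccc(Cl)c3)nc(-c3cccs3)c2)c1` — in this assay compound 2 gives 3410 nM
- compound 3, `Oc1cccc(-c2cc(-c3ccccc3)nc(-c3ccccc3Cl)c2)c1` — in this assay compound 3 gives 2920 nM

Compound 3 and compound 2 sit close together; the gap between their two numbers lies within the scatter of this assay, so neither can be called the stronger inhibitor. Compound 1 adds no number.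

Compound 4, `Oc1cccc(-c2cc(-c3ccccc3)nc(-c3cccc(Cl)c3)c2)c1`, differs from compound 3 by a single rearrangement: 3-chlorophenyl in place of 2-chlorophenyl on an aromatic carbon. Among the measured compounds shown here, no step of this kind is available among the measured compounds, so there is no direct precedent. Compound 2 already carries a 3-chlorophenyl group and its half-maximal inhibitory concentration is close to that of compound 3. On this basis the expected step from compound 3 to compound 4 is small, in no settled direction, and likely not beyond the scatter: a 1.0-fold higher number from compound 3 to compound 4 (0.01 log units; within the scatter). Compound 4 is estimated at 3000 nM in this assay, with a range from 1200 nM to 7500 nM.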

Compound 4, half-maximal inhibitory concentration: 3700 nM
The estimate for compound 4 lay 1.2-fold (0.09 log units) below the measured number, and the stated range covers the measured number.
By their numbers in this assay, from the lowest: compounds 3, 2 and 4 (each within the scatter of the next).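

Moving the chlorine on the aryl group next to the ring nitrogen, with 3-chlorophenyl in place of 2-chlorophenyl, gives the first step read at this position, a 1.3-fold higher number from compound 3 to compound 4 (0.10 log units; within the scatter) in this assay, so the two placements of the chlorine cannot be told apart here. A second step, with phenyl in place of thiophen-2-yl, gives a 1.1-fold higher number from compound 2 to compound 4 (0.04 log units; within the scatter) and likewise stays inside the scatter, so this pair gives no ground for separating the two arrangements of the flanking groups. No supporting data bear on the reason for either result.

On these data alone, whether an amine or a carboxylic acid in place of the chlorine would move the number beyond the scatter remains open. The group that sets compound 1 apart from compound 2 also stays unread, since compound 1 gives "not determined" (no result reported) in this series.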